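This account rests on a few compounds, and the source may have more. Where it says the series, first, only, none or still open, it means among the compounds named here.

Compound 1 `Cc1ccc2c(NCc3ccc(NC(=O)C4CCN(Cc5ccc(Cl)cc5)CC4)cc3)nc(N(C)C)nc2c1` gives > 3180 nM in a functional assay on SV5A8 cells (Homo sapiens) for cytotoxicity (on this read-out lower numbers stand for stronger inhibition and higher numbers for weaker inhibition), a limit of the assay rather than a number.
Compound 2 `Cc1ccc2c(NCc3ccc(NC(=O)C4CCN(Cc5ccccc5)CC4)cc3)nc(N3CCNC(CCO)C3)nc2c1` gives > 8420 nM in this assay, likewise a limit rather than a number.

Compound 1 therefore stands at the limit of > 3180 nM in this assay, at which 1 of the 2 values shown sits, and the second value stands at the limit of > 8420 nM in this assay, at which 1 of the 2 values shown sits; neither measurement gives a number that could be ranked against the other. Compound 3 `Cc1ccc2c(NCc3ccc(NC(=O)C4CCN(Cc5ccco5)CC4)cc3)nc(N(C)C)nc2c1` differs from compound 1 in one place: furan-2-yl in place of 4-chlorophenyl on a saturated chain carbon bound to an amine nitrogen in a ring. Among the compounds with values here, no step between measured compounds is available, so there is nothing to show how far a swap of this kind moves the read-out. Because compound 1 sits at the limit of > 3180 nM in this assay, at which 1 of the 2 values shown sits, compound 3 is expected to remain in the same weak region. The step that the limit leaves unreadable from compound 1 to compound 3 is expected to be none beyond the scatter. Compound 3 is estimated at 6000 nM, between 1500 nM and 30000 nM, and most likely the assay will again report only a limit.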

Compound 3, half-maximal inhibitory concentration: > 20000 nM
Compound 3 ended at the assay's limit (the forecaster's own chance of this, stated with the estimate: 75%); middle value at least 3.3-fold (0.52 log units) from the limit.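

Within the data shown here, compound 1 and compound 3 both end at limits rather than numbers, so no step between them can be read. The compounds shown leave open whether furan-2-yl in place of 4-chlorophenyl changes the result in this assay at all, and by how much.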